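Swapping phenyl for propyl on the hydroxy carbon of compound 2

This account rests on a few compounds, and the source may have more. Where it says the series, first, only, none or still open, it means among the compounds named here.

Measured compounds:
compound 1 `CCOC(=O)CC1C(C(=O)OCC)=C(N)Oc2ccc(-c3cc(OC)cc(OC)c3)cc21`: 5400 nM
compound 2 `C#CCOC(=O)C1=C(N)Oc2ccc(-c3cc(OC)cc(OC)c3)cc2C1CC(O)c1ccccc1`: 100000 nM
compound 3 `C#CCOC(=O)CC1C(C(=O)OCC#C)=C(N)Oc2ccc(-c3cccc(N)c3)cc21`: 1730 nM

In a functional assay on HL-60 cells (Homo sapiens) for inhibition, with a stated time of 48 h (on this read-out lower numbers stand for stronger inhibition and higher numbers for weaker inhibition), compound 2 gives 100000 nM, the highest of the three numbers; compound 1 and compound 3 both sit far lower, beyond the scatter. Compound 4 `C#CCOC(=O)C1=C(N)Oc2ccc(-c3cc(OC)cc(OC)c3)cc2C1CC(O)CCC` differs from compound 2 in a single place: propyl in place of phenyl on a saturated chain carbon bound to an oxygen on a saturated carbon and a saturated chain carbon. Within the data shown here, no measured pair shows this change, so its effect is unknown; the account rests on compound 2 alone. With no evidence that the propyl chain would help, compound 4 is expected to stay near the weak end, with an estimated step of a 1.4-fold lower number from compound 2 to compound 4 (0.15 log units; within the scatter) that lies within the scatter. Compound 4 is therefore estimated at 70000 nM, in a range from 20000 nM to 200000 nM.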

Compound 4, half-maximal inhibitory concentration: 46600 nM
Compound 4: middle estimate off by 1.5-fold (0.18 log units), on the high side; measured number inside the range.
By their numbers in this assay, from the lowest: compound 3; then compound 1; then compound 4; then compound 2.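

In this assay, among these compounds, replacing phenyl with propyl on the hydroxy-bearing carbon gives the first measured one-place change at this position (a 2.1-fold lower number from compound 2 to compound 4 (0.33 log units; beyond the scatter)). The step is modest but beyond the usual scatter, so this position does respond to its substituent, and an aromatic ring there is not required for the inhibition seen with compound 4. Nothing available explains the step.

Going by these compounds, whether a longer chain such as pentyl, or an amine on that chain, would lower the number further remains open. So does whether this step would carry over to other compounds in the series.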